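Removing One Ring Methyl From Compound 1

A few compounds are considered here, and "the series" means these few. Any claim that something is new, unique, unknown or untested is made for them only; others in the source may bear on it.

In a functional assay for inhibition, with Homo sapiens as the target (on this read-out higher numbers stand for weaker inhibition and lower numbers for stronger inhibition), compound 1 (`Cc1cc2c(cc1C(=O)N=C(N)N)S(=O)(=O)CCC2C`) gives 655 nM. Compound 2 (`Cc1cc2c(cc1C(=O)N=C(N)N)S(=O)(=O)C(C)(C)CC2C`) gives 1100 nM, which lies within the scatter of compound 1. Compound 3 (`Cc1cc2c(cc1C(=O)N=C(N)N)S(=O)(=O)CCCC2`) gives 274 nM, a lower number than compound 1 and beyond the scatter. Compound 1 therefore stands in the upper part of this small set, level with compound 2 within the scatter.

Compound 4 (`Cc1cc2c(cc1C(=O)N=C(N)N)S(=O)(=O)CCC2`) has not yet been measured. It differs from compound 1 by hydrogen in place of methyl on a saturated ring carbon, with hydrogen in place of methyl on a saturated ring carbon. Going by the values given here, no measured pair isolates this change, so its size has no direct precedent. A modest step toward a lower number in this assay is expected, and it may not exceed the scatter. Among the compounds with values here, the only support is compound 3, which has no methyl on its saturated ring carbons and reads 274 nM, though it differs in other ways too.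

The estimate amounts to an expected 1.6-fold lower number from compound 1 to compound 4 (0.19 log units; within the scatter). For compound 4 the estimated value is 420 nM, with an expected range from 170 nM to 1000 nM.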

Compound 4, half-maximal inhibitory concentration: 14300 nM
Beside the measured number, compound 4's estimate is 34-fold (1.53 log units) below it; measured number above the stated range.
By their numbers in this assay, from the lowest: compound 3; then compounds 1 and 2 (each within the scatter of the next); then compound 4.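

Going by these compounds alone, this is the first pair that isolates the methyl on this saturated ring carbon, three ring bonds from the ring sulfur. In this assay, replacing that methyl with hydrogen gives a 22-fold higher number from compound 1 to compound 4 (1.34 log units; beyond the scatter), so the loss of one carbon at this place is enough to weaken inhibition markedly, and the methyl is far from a dispensable part of compound 1. Nothing shown accounts for the size of this step.

The compounds shown leave open whether an ethyl group, a longer chain, a hydroxyl group or an amine on this carbon would keep the number of compound 1, lower it further or raise it toward that of compound 4. They also leave open whether the same replacement would give a step of this size on a core that differs elsewhere.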